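Fluoro in place of chloro: from compound 3 to compound 4

The source may report more compounds than this note shows. Statements on the series, on what has been measured and on what is new or still open speak of the compounds shown alone.

Of the compounds shown here, three sharing one core have been measured in a physicochemical assay, with a stated time of 6 min; on this read-out higher numbers stand for weaker inhibition and lower numbers for stronger inhibition. Compound 1 `O=C(Nc1ccc(Br)cc1)Nc1nc(-c2cc3ccccc3o2)cs1` returns only a limit of the assay, > 200000 nM. Compound 2 `COc1cccc(NC(=O)Nc2nc(-c3cc4ccccc4o3)cs2)c1` gives 200 nM. Compound 3 `O=C(Nc1cccc(Cl)c1)Nc1nc(-c2cc3ccccc3o2)cs1` gives 14100 nM, the highest of the numbers that are not limits.

Compound 4 `O=C(Nc1cccc(F)c1)Nc1nc(-c2cc3ccccc3o2)cs1` has fluoro in place of chloro on an aromatic carbon, meta to a large group. Within the data shown here, two measured steps bear on this change. Chloro in place of methoxy at the same place gave a 71-fold higher number from compound 2 to compound 3 (1.85 log units; beyond the scatter), and 3-chlorophenyl in place of 4-bromophenyl gave an at least 14-fold lower number from compound 1 to compound 3 (1.15 log units; beyond the scatter). Both steps are large, so among these three compounds the substituted phenyl strongly affects the read-out of this assay. Neither step, however, swaps chloro for fluoro at one place, so they indicate how wide the uncertainty should be rather than the size of this step.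

The present exchange is a single atom for a single atom, so a modest shift towards a lower number is expected, much smaller than those steps. The expected step is a 1.6-fold lower number from compound 3 to compound 4 (0.19 log units; within the scatter). Compound 4 is estimated at 9000 nM, with an expected range of 2000 nM to 40000 nM.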

Compound 4, half-maximal inhibitory concentration: 4520 nM
For compound 4 the middle estimate is 2.0-fold (0.30 log units) above the measured one; low and high end bracket the measured number.
By their numbers in this assay, from the lowest: compound 2; then compound 4; then compound 3. At a limit, above all of these: compound 1.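

In this assay, fluoro in place of chloro on this aromatic carbon gives a 3.1-fold lower number from compound 3 to compound 4 (0.49 log units; beyond the scatter), which shows that exchanging one halogen for the other at this place is enough to move the number beyond the scatter. The change remains modest beside the step from methoxy to fluoro at the same place, a 23-fold higher number from compound 2 to compound 4 (1.35 log units; beyond the scatter), so with either halogen here the number stays well above that of compound 2, and the choice between the halogens matters far less than the loss of methoxy. The step of an at least 44-fold lower number from compound 1 to compound 4 (1.64 log units; beyond the scatter) is large, but it starts from a limit and not from a number, so it fixes only a minimum size for the change from 4-bromophenyl to 3-fluorophenyl: the limit of > 200000 nM in this assay, at which 1 of the 4 values shown sits.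

The compounds shown leave open whether an amine, a hydroxyl or an ethoxy group at this place would give a number closer to that of compound 2 or to those of the two halogens. They also cannot separate the effect of the bromo atom from the effect of its place, since 4-bromophenyl differs from 3-fluorophenyl and 3-chlorophenyl in both.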